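Triazine Acrylamides in Ramos Cells: From Amide to Biaryl

The compounds below may be only part of what the source reports. "The series", "measured", "known", "first", "only" and "open" are said of these compounds alone.

Measured compounds:
compound 1, `C=CC(=O)Nc1cccc(Nc2ncnc(Nc3ccc(C(=O)Nc4ccccn4)cc3)n2)c1`, "not determined" (no result reported)
compound 2, `C/C=C/C(=O)Nc1cccc(Nc2ncnc(Nc3ccc(C(=O)N4CCCCC4)cc3)n2)c1`, 13200 nM

The series is assessed in a functional assay on Ramos cells (Homo sapiens) for antiproliferative activity, read by CCK-8 assay, with a stated time of 24 h; on this read-out higher numbers stand for weaker inhibition and lower numbers for stronger inhibition. Compound 1 carries a (pyridin-2-yl)carbamoyl group on the aromatic carbon para to the large group, but for compound 1 no number is recorded in this assay, so it stands nowhere on the scale shown here. Among the compounds with values here, compound 2, which differs from compound 1 in more than one place, is the only compound with a figure: in this assay compound 2 gives 13200 nM, a weak result. Within the data shown here, the two differ in several places, so no step between them can be counted. Only their values can be set side by side, one of which is missing.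

Compound 3, `C=CC(=O)Nc1cccc(Nc2ncnc(Nc3ccc(-c4ccc(F)nc4)cc3)n2)c1`, arises from compound 1 by the change (6-fluoropyridin-3-yl in place of (pyridin-2-yl)carbamoyl on an aromatic carbon). With no measured anchor for compound 1, the size of this step cannot be read from anything shown; any direction is open, and a step beyond the scatter in either sense is as plausible as none. The expectation for compound 3 therefore rests on the weak figure of compound 2 and on wide uncertainty: compound 3 is estimated at 5000 nM, within a range from 800 nM to 30000 nM.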

Compound 3, half-maximal inhibitory concentration: 59200 nM
Compound 3: the middle estimate sits 12-fold (1.07 log units) below what was measured; the measured number lies above the stated range.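

In this assay no step can be read from compound 1 to compound 3, as compound 1 has no number there to compare. The compounds shown leave open how exchanging (pyridin-2-yl)carbamoyl for 6-fluoropyridin-3-yl changes activity on this read-out. Nothing shown bears on why compound 3 gives the figure it does.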